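The source may hold more compounds than are shown below. What is called first, only, known or untested is meant among the compounds shown, and "the series" means these compounds.

Measured in a toxicity assay on microsomes from liver (Homo sapiens) for metabolic stability, read by LC-MS, using NADPH, tested at 1 uM; a lower number here means slower removal, a higher number faster removal of the compound:
- compound 1 `CCOc1ncc(-c2nc(C(F)(F)F)sc2N2CCN(C(=O)Cn3ccc4cccnc43)[C@H](C)C2)cn1`: 316 mL.min-1.g-1
- compound 2 `CCOc1ncc(-c2nc(C(F)(F)F)sc2N2CCN(C(=O)Cn3ccc4cnccc43)[C@H](C)C2)cn1`: 656 mL.min-1.g-1

Compound 2 has the higher of these two numbers. Compound 3 `CCOc1ncc(-c2nc(C(F)(F)F)sc2N2CCN(C(=O)Cn3ncc4cccnc43)[C@H](C)C2)cn1` alters compound 2 on a saturated chain carbon bound to a carbonyl carbon: a group of 9 heavy atoms (6 carbon, 3 nitrogen; one five-membered aromatic ring with 2 hetero atoms, one six-membered aromatic ring with 1 hetero atom) in place of a group of 9 heavy atoms (7 carbon, 2 nitrogen; one five-membered aromatic ring with 1 hetero atom, one six-membered aromatic ring with 1 hetero atom), on a saturated chain carbon bound to a carbonyl carbon. Among the compounds with values here, the only measured step that bears on this is a 2.1-fold higher number from compound 1 to compound 2 (0.32 log units; beyond the scatter), a swap at the same place. The entering group looks closer in layout to that of compound 1, which gives 316 mL.min-1.g-1. A change of similar size towards a lower number in this assay therefore seems likely. The expected step is a 2.1-fold lower number from compound 2 to compound 3 (0.31 log units; beyond the scatter). The estimated value for compound 3 is 320 mL.min-1.g-1, with an expected range of 140 mL.min-1.g-1 to 700 mL.min-1.g-1.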

Compound 3, intrinsic clearance in microsomes: 41 mL.min-1.g-1
Beside the measured number, compound 3's estimate is 7.8-fold (0.89 log units) above it; measured number outside the range, below it.
By their numbers in this assay, from the lowest: compound 3; then compound 1; then compound 2.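

In this assay, the group on a saturated chain carbon bound to a carbonyl carbon can shift the number much more than the step between compound 1 and compound 2 suggested. The group with 2 hetero atoms in its five-membered aromatic ring gives the lowest number of the three, both against compound 2 (a 16-fold lower number from compound 2 to compound 3 (1.20 log units; beyond the scatter)) and against compound 1 (a 7.7-fold lower number from compound 1 to compound 3 (0.89 log units; beyond the scatter)). Nothing shown here explains this drop.
Still open, on these data alone, is how a fused group with 3 nitrogens in its five-membered aromatic ring, such as a triazolopyridine, would behave. Also open, as far as these compounds go, is whether a plain indole would give a higher number than these three.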